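From fluoro to chloro on compound 2

This account rests on a few compounds, and the source may have more. Where it says the series, first, only, none or still open, it means among the compounds named here.

Measured in a functional assay on MCF7 cells (Homo sapiens) for inhibition, read by CCK-8 assay, with a stated time of 48 h; on this read-out lower numbers stand for stronger inhibition and higher numbers for weaker inhibition:
Compound 1 `COc1cc(-c2cc3nccc(-c4cc(OC)c(OC)c(OC)c4)n3n2)cc(OC)c1OC`: > 10000 nM (a limit)
Compound 2 `COc1cc(-c2ccnc3cc(-c4ccc(F)cc4)nn23)cc(OC)c1OC`: 1280 nM
Compound 3 `COc1cc(-c2ccnc3cc(-c4cn(CO)c5ccccc45)nn23)cc(OC)c1OC`: 19 nM

The entry for compound 1, > 10000 nM, is a limit and not a number. That leaves two numbers to compare. Compound 2 gives 1280 nM, the higher of the two, and so the weaker inhibition. Compound 3 gives 19 nM, and the gap between these two lies beyond the scatter.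

The next compound to be tested is compound 4 `COc1cc(-c2ccnc3cc(-c4ccc(Cl)cc4)nn23)cc(OC)c1OC`, which has chloro in place of fluoro on an aromatic carbon. The change turns 4-fluorophenyl into 4-chlorophenyl, and everything else stays as in compound 2. Among the measured compounds shown here, no measured pair in this set tests such a swap, so the expectation is anchored on compound 2 at 1280 nM. In this assay, no step beyond the scatter is expected, and neither direction is favoured. The expected change is a 1.2-fold lower number from compound 2 to compound 4 (0.07 log units; within the scatter). For compound 4 the estimated value is 1100 nM, with an expected range from 350 nM to 3500 nM.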

Compound 4, half-maximal inhibitory concentration: 2320 nM
Beside the measured number, compound 4's estimate is 2.1-fold (0.32 log units) below it; low and high end bracket the measured number.
By their numbers in this assay, from the lowest: compound 3; then compounds 2 and 4 (each within the scatter of the next). At a limit, above all of these: compound 1.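

In this assay, chloro in place of fluoro on an aromatic carbon, para to a large group, gives a 1.8-fold higher number from compound 2 to compound 4 (0.26 log units; within the scatter). Among the compounds shown here, this is the first pair in the set that differs in one place, and it shows that 4-fluorophenyl and 4-chlorophenyl cannot be told apart here, since the step stays within the scatter. Compound 4, like compound 2, gives a number, and only compound 1 stands at a limit: the limit of > 10000 nM in this assay, at which 1 of the 4 values shown sits.

Going by these compounds, only these two halogens appear at this position, so what an amine, a carboxylic acid or a longer chain such as propoxy would do there remains open. Whether the same exchange of fluoro for chloro would also stay within the scatter on another core is open as well.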